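Two compounds at the assay limit, a third awaited

This account rests on a few compounds, and the source may have more. Where it says the series, first, only, none or still open, it means among the compounds named here.

Measured so far:
compound 1 `CCC1(c2ccccc2)CC(=O)C(C2CC(c3ccc(OCc4ccc(C(F)(F)F)cc4)cc3)Cc3ccccc32)=C(O)O1` with > 10000 nM
compound 2 `CCCC1(CCc2ccccc2)CC(=O)C(C2CC(c3ccc(-c4ccc(Br)cc4)cc3)Cc3ccccc32)=C(O)O1` with > 10000 nM

In a functional assay on SK-OV-3 cells (Homo sapiens) for inhibition, with a stated time of 72 h (a higher number here means a weaker inhibitor, a lower number a stronger inhibitor), compound 2 gives > 10000 nM, which is a limit of the assay rather than a number. Compound 1 gives > 10000 nM, likewise a limit. Both values shown sit at this limit, (the limit of > 10000 nM in this assay, at which 2 of the 2 values shown sit). Compound 3 `CCCC1(CCc2ccccc2)CC(=O)C(C2CC(c3ccc(OCc4ccc(C(F)(F)F)cc4)cc3)Cc3ccccc32)=C(O)O1` is not yet measured; it differs from compound 2 by (4-(trifluoromethyl)benzyl)oxy in place of 4-bromophenyl on an aromatic carbon. Going by the values given here, no measured step covers this change, so its size is unknown; still, compound 1 carries the same entering group and gives > 10000 nM. Compound 3 is therefore expected to stay at the limit, estimated at 15000 nM within 5000 nM to 50000 nM. The expected step that the limit leaves unreadable from compound 2 to compound 3 is nothing beyond the scatter.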

Compound 3, half-maximal inhibitory concentration: > 10000 nM
Compound 3: a limit, no number; the forecaster's own chance of this, stated with the estimate: 80%; the middle value does not contradict the limit.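

Compound 2 and compound 3 both stand at a limit, so the step between them cannot be read: the limit of > 10000 nM in this assay, at which 3 of the 3 values shown sit. The compounds shown leave open whether exchanging 4-bromophenyl for (4-(trifluoromethyl)benzyl)oxy changes inhibition at all.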